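Swapping 3-fluorophenyl for 4-methoxyphenyl in compound 3

The source may hold more compounds than are shown below. What is called first, only, known or untested is meant among the compounds shown, and "the series" means these compounds.

- Compound 1 `O=C(CCc1cccc2c1B(O)OC2)Nc1cccc(Br)c1` gives 1400 nM
- Compound 2 `CC(C)c1cccc(NC(=O)CCc2cccc3c2B(O)OC3)c1` gives 1600 nM
- Compound 3 `O=C(CCc1cccc2c1B(O)OC2)Nc1cccc(-c2cccc(F)c2)c1` gives 460 nM

In a functional assay on HCT-116 cells (Homo sapiens) for antiproliferative activity, read by MTT assay, with a stated time of 72 h (on this read-out higher numbers stand for weaker inhibition and lower numbers for stronger inhibition), compound 3 stands lowest of the three at 460 nM and lies beyond the scatter from both others. Two modest steps bear on what comes next: a 3.0-fold lower number from compound 1 to compound 3 (0.48 log units; beyond the scatter) with 3-fluorophenyl in place of bromo, and a 3.5-fold lower number from compound 2 to compound 3 (0.54 log units; beyond the scatter) with 3-fluorophenyl in place of isopropyl. Compound 4 `COc1ccc(-c2cccc(NC(=O)CCc3cccc4c3B(O)OC4)c2)cc1` has 4-methoxyphenyl in place of 3-fluorophenyl on an aromatic carbon, meta to a large group (4-methoxyphenyl in place of 3-fluorophenyl on an aromatic carbon). Among the compounds with values here, no measured step swaps one substituted phenyl for another, so in this assay no step beyond the scatter is expected. The expected step is a 1.1-fold higher number from compound 3 to compound 4 (0.04 log units; within the scatter) in size. Compound 4 is estimated at 500 nM (range 200 nM to 1250 nM).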

Compound 4, half-maximal inhibitory concentration: 160 nM
Compound 4: the middle estimate sits 3.1-fold (0.49 log units) above what was measured; the measured number lies below the stated range.
By their numbers in this assay, from the lowest: compound 4; then compound 3; then compounds 1 and 2 (each within the scatter of the next).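

In this assay the choice of substituent on the phenyl group still counts at this position, with a 2.9-fold lower number from compound 3 to compound 4 (0.46 log units; beyond the scatter) on exchanging 3-fluorophenyl for 4-methoxyphenyl. Set against the earlier groups, 4-methoxyphenyl gives an 8.8-fold lower number from compound 1 to compound 4 (0.94 log units; beyond the scatter) in place of bromo and a 10-fold lower number from compound 2 to compound 4 (1.00 log units; beyond the scatter) in place of isopropyl, which leaves compound 4 with the lowest number of the four. Nothing at hand explains this difference. From the compounds shown here alone, whether the methoxy group or its place on the phenyl ring accounts for the step stays open, and so does how a 4-hydroxyphenyl or 4-aminophenyl group would compare here.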